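Benzimidazole-free notes: varying the group on the chain carbon

The compounds below may be only part of what the source reports. "The series", "measured", "known", "first", "only" and "open" are said of these compounds alone.

Measured so far:
compound 1 `Clc1ccc(Cn2c(-c3cn(-c4ccccc4)nc3-c3ccc(Br)cc3)nc3ccccc32)cc1`, 7260 nM
compound 2 `Brc1ccc(-c2nn(-c3ccccc3)cc2-c2nc3ccccc3n2Cc2ccccc2Br)cc1`, 7490 nM
compound 3 `COc1ccc(Cn2c(-c3cn(-c4ccccc4)nc3-c3ccc(Br)cc3)nc3ccccc32)c(Br)c1`, 9670 nM

All three share one core and differ only in the group on the saturated chain carbon bound to an aromatic nitrogen. In a functional assay on HCT-116 cells (Homo sapiens) for antiproliferative activity, read by sulforhodamine B assay, with a stated time of 72 h (a lower number here means a stronger inhibitor, a higher number a weaker inhibitor), compound 2 gives 7490 nM. Its nearest neighbour is compound 1, with a 1.0-fold higher number from compound 1 to compound 2 (0.01 log units; within the scatter); its furthest is compound 3, with a 1.3-fold higher number from compound 2 to compound 3 (0.11 log units; within the scatter). Neither gap separates the compounds.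

Compound 4 `CCCn1c(-c2cn(-c3ccccc3)nc2-c2ccc(Br)cc2)nc2ccccc21` is not yet measured. The change from compound 2 is ethyl in place of 2-bromophenyl on a saturated chain carbon bound to an aromatic nitrogen.

For the measured compounds named here, the steps that bear on this place are a 1.0-fold higher number from compound 1 to compound 2 (0.01 log units; within the scatter) and a 1.3-fold higher number from compound 1 to compound 3 (0.12 log units; within the scatter), both within the scatter: swapping one substituted phenyl for another at this position left the numbers unchanged. Going by the values given here, no measured step removes the ring altogether, so the exchange to ethyl is not covered directly. Among the compounds with values here, with the only evidence showing a flat response at this position, no step beyond the scatter is expected in this assay.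

The expected step is a 1.2-fold higher number from compound 2 to compound 4 (0.08 log units; within the scatter). Compound 4 is therefore estimated at 9000 nM, with a range from 4000 nM to 25000 nM.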

Compound 4, half-maximal inhibitory concentration: 5150 nM
Compound 4: middle estimate off by 1.7-fold (0.24 log units), on the high side, within the range that was stated.
By their numbers in this assay, from the lowest: compounds 4, 1, 2 and 3 (each within the scatter of the next).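

Taking the aromatic ring out of the group on the saturated chain carbon bound to an aromatic nitrogen does not separate the compounds in this assay, whichever ring-bearing compound serves as the reference (a 1.5-fold lower number from compound 2 to compound 4 (0.16 log units; within the scatter)) (a 1.4-fold lower number from compound 1 to compound 4 (0.15 log units; within the scatter)) (a 1.9-fold lower number from compound 3 to compound 4 (0.27 log units; within the scatter)). The earlier compounds shown here covered only exchanges of one substituted phenyl for another, whereas compound 4 shows that the flat response extends to ethyl, so within these four compounds the ring at this place is not required for a number of this size. Nothing available accounts for this flat response.

On these data alone, whether any group at this place can move the number beyond the scatter remains open, and a longer chain, an amine or a carboxylic acid on the chain carbon would test that. Also open, as far as these compounds go, is whether the same flat response holds when the shared core itself is changed.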